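A few compounds are considered here, and "the series" means these few. Any claim that something is new, unique, unknown or untested is made for them only; others in the source may bear on it.

Measured so far in a functional assay on the whole organism for antagonist activity, with Mus musculus as the target; a lower number here means that less compound is needed, a higher number that more compound is needed for the effect:
Compound 1, `CC(C#CCn1ccnc1)N1CCCC1=O`, gives 3.7 mg/kg.
Compound 2, `CC(C#CCN(C)C)N1CCCC1=O`, gives only a limit of the assay, > 100 mg/kg.
Compound 3, `COC(=O)N(C)C(C)C#CCn1ccnc1`, gives only a limit of the assay, > 100 mg/kg.

Compound 1 and compound 2 differ in one place: dimethylamino in place of 1H-imidazol-1-yl on a saturated chain carbon bound to a triple-bonded carbon. In this assay that change made an at least 27-fold higher number from compound 1 to compound 2 (1.43 log units; beyond the scatter), so the measured member of the pair with dimethylamino is not pinned to a number at all. Compound 3 shares the 1H-imidazol-1-yl group with compound 1 but differs from it in more than one place; the difference between the two cores is not broken down here.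

The unmeasured compound 4, `COC(=O)N(C)C(C)C#CCN(C)C`, stands to compound 3 as compound 2 stands to compound 1: dimethylamino in place of 1H-imidazol-1-yl on a saturated chain carbon bound to a triple-bonded carbon. The place is the same word for word, so this is the same change, made on the core of compound 3 instead of the core of compound 1.

Two points bear on the expectation. Compound 3 already sits at a limit of the assay. For the measured compounds named here, the one measured instance of this change, an at least 27-fold higher number from compound 1 to compound 2 (1.43 log units; beyond the scatter), moved the number upward by a large step, and two of the three values shown sit at the limit of > 100 mg/kg in this assay, at which 2 of the 3 values shown sit. The step from compound 3 to compound 4 is therefore expected to be flat or upward, roughly a step that the limit leaves unreadable from compound 3 to compound 4, with the true size hidden by the limit. Compound 4 is expected around 400 mg/kg, somewhere between 100 mg/kg and 3000 mg/kg, and most probably this assay will report only a limit for it again.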

Compound 4, dose for half-maximal effect: > 100 mg/kg
Compound 4: no number, only a limit; the forecaster's own chance of this, stated with the estimate: 95%; the middle value lies beyond the limit too.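

In this assay, for the compounds shown here, compound 4 gives only a limit of the assay, > 100 mg/kg, and compound 3 likewise gives only a limit, so no step from compound 3 to compound 4 can be read. Compound 4 joins the other values at that limit: the limit of > 100 mg/kg in this assay, at which 3 of the 4 values shown sit.

Left open is whether dimethylamino in place of 1H-imidazol-1-yl changes the number at all on the core of compound 3, as it does on the core of compound 1.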